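A few compounds are considered here, and "the series" means these few. Any claim that something is new, unique, unknown or untested is made for them only; others in the source may bear on it.

Of the compounds shown here, three have so far been tested in an ADME assay on HS27 cells (Homo sapiens) for cytotoxicity, read by MTT assay, with a stated time of 24 h; a lower number here means a stronger inhibitor of growth, a higher number a weaker inhibitor of growth. In this assay compound 1 `Cc1ccc(NC(=O)Nc2cc(Cl)cc(Cl)c2)cc1NC(=O)c1cnoc1C` gives > 30000 nM, which is a limit of the assay rather than a number. Compound 2 `Cc1ccc(NC(=O)Nc2ccc(Cl)c(Cl)c2)cc1NC(=O)c1cnoc1C` likewise gives > 30000 nM, again only a limit. Compound 3 `Cc1cc(NC(=O)Nc2ccc(Cl)c(Cl)c2)ccc1NC(=O)c1cnoc1C` also gives > 30000 nM, a limit as well. Compound 2 and compound 1 differ in a single place (3,5-dichlorophenyl in place of 3,4-dichlorophenyl on an amide-type nitrogen), and the step that the two limits leave unreadable from compound 2 to compound 1 cannot be read because of the limit of > 30000 nM in this assay, at which 3 of the 3 values shown sit. The cores of compound 2 and compound 3 differ too, but that difference is not broken down here. Within the data shown here, compound 4 `Cc1cc(NC(=O)Nc2cc(Cl)cc(Cl)c2)ccc1NC(=O)c1cnoc1C` has not yet been measured; it differs from compound 3 in exactly the same way (3,5-dichlorophenyl in place of 3,4-dichlorophenyl on an amide-type nitrogen), at a place described in the same words, so it is the same change as the one from compound 2 to compound 1. Resting on the earlier step that the two limits leave unreadable from compound 2 to compound 1, which never left the limit, the expected step is a step that the limit leaves unreadable from compound 3 to compound 4. Compound 4 is therefore expected to give about 40000 nM, most probably reported once more as a limit.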

Compound 4, concentration for 50% growth inhibition: > 30000 nM
Compound 4: no number, only a limit; the forecaster's own chance of this, stated with the estimate: 90%; the middle value does not contradict the limit.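

In this assay compound 4 gives > 30000 nM, which is a limit and not a number. No new step can be read between compound 3 and compound 4, because the values stop at the same limit: the limit of > 30000 nM in this assay, at which 4 of the 4 values shown sit. The compounds shown leave open how far swapping 3,4-dichlorophenyl for 3,5-dichlorophenyl shifts growth inhibition, if at all.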